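Returning to a Benzyl Arm, Now Methylated

This account rests on a few compounds, and the source may have more. Where it says the series, first, only, none or still open, it means among the compounds named here.

Two measured compounds share one core and differ only in the group on a saturated ring carbon. Compound 1 `c1ccc(CNCC2CCN(CCCc3c[nH]c4ccc(-n5cnnc5)cc34)CC2)cc1` carries a (benzylamino)methyl group there, and in a functional assay on CHO cells for activation of 5-hydroxytryptamine receptor 1D (Homo sapiens), read by GTPgammaS binding (a higher number here means a larger maximal response, a lower number a smaller maximal response), compound 1 reaches 101%. Compound 2 `c1cc(CNC2CCN(CCCc3c[nH]c4ccc(-n5cnnc5)cc34)CC2)co1` carries a ((furan-3-yl)methyl)amino group instead, and in this assay compound 2 reaches 65%, the lower of the two numbers. Among the compounds with values here, the step of a number 36 percentage points lower from compound 1 to compound 2 (beyond the scatter) is the only measured comparison available.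

Compound 3 `CN(Cc1ccccc1)CC1CCN(CCCc2c[nH]c3ccc(-n4cnnc4)cc23)CC1` has not yet been measured. (benzyl(methyl)amino)methyl in place of ((furan-3-yl)methyl)amino on a saturated ring carbon This change largely undoes the step from compound 1 to compound 2, since the benzyl group returns, now as (benzyl(methyl)amino)methyl. Because a number 36 percentage points lower from compound 1 to compound 2 (beyond the scatter) was large, a step of similar size in the opposite direction is expected in this assay, namely a number 30 percentage points higher from compound 2 to compound 3 (beyond the scatter). Compound 3 is therefore expected to reach about 95%, with a likely range from 75% to 110%.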

Compound 3, largest response reached (reported as efficacy), in percent of the reference or control that the assay uses: 93%
Compound 3: the middle estimate sits 2 percentage points above what was measured, within the range that was stated.
By their numbers in this assay, from the lowest: compound 2; then compounds 3 and 1 (each within the scatter of the next).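

Putting a methyl on the amine nitrogen of the benzyl arm leaves this assay essentially unchanged, a number 8 percentage points lower from compound 1 to compound 3 (within the scatter). The high maximal response therefore does not need a hydrogen-bond donor on this nitrogen, as the entering group in compound 3 has 0 such donors. The response also returns with the benzyl-bearing group, a number 28 percentage points higher from compound 2 to compound 3 (beyond the scatter), but this step replaces the whole group, so it cannot show whether the aromatic ring, the attachment to the saturated ring or the amine substitution matters most.

Going by these compounds, it remains open how an ethyl group on this nitrogen, or a benzylamino group placed directly on the saturated ring carbon, would behave. No available measurement explains why these groups give different maximal responses.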